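Benzyloxy Substitution and Cytotoxicity in a Bis-Chalcone Series

A few compounds are considered here, and "the series" means these few. Any claim that something is new, unique, unknown or untested is made for them only; others in the source may bear on it.

Measured compounds:
compound 1 `Cc1cc(O)c(C(=O)/C=C/c2ccc(Br)cc2)c(-c2ccc(OCc3ccccc3)cc2)c1C(=O)/C=C/c1ccc(Br)cc1`: 20000 nM
compound 2 `COc1ccc(/C=C/C(=O)c2c(C)cc(O)c(C(=O)/C=C/c3ccc(OC)c(OC)c3)c2-c2ccccc2)cc1OC`: "not active" (no number reported)
compound 3 `Cc1cc(O)c(C(=O)/C=C/c2ccc(Br)cc2)c(-c2ccccc2)c1C(=O)/C=C/c1ccc(Br)cc1`: 10000 nM

In an ADME assay on HEK293 cells (Homo sapiens) for cytotoxicity, read by MTT assay, with a stated time of 24 h (a higher number here means a weaker inhibitor, a lower number a stronger inhibitor), compound 3 gives 10000 nM, and compound 1 gives 20000 nM. The change between them is benzyloxy in place of hydrogen on an aromatic carbon, and it made the step of a 2.0-fold higher number from compound 3 to compound 1 (0.30 log units; within the scatter). Compound 2 is recorded as "not active" (no number reported) in this assay, so no single number stands for it. How the core of compound 2 differs from the core of compound 3 is not broken down here. Compound 4 `COc1ccc(/C=C/C(=O)c2c(C)cc(O)c(C(=O)/C=C/c3ccc(OC)c(OC)c3)c2-c2ccc(OCc3ccccc3)cc2)cc1OC` is not yet measured; it differs from compound 2 by benzyloxy in place of hydrogen on an aromatic carbon, the same change as from compound 3 to compound 1. Because a 2.0-fold higher number from compound 3 to compound 1 (0.30 log units; within the scatter) lay within the scatter, a similarly small step is expected from compound 2 to compound 4 in this assay. Compound 4 is therefore expected to give 40000 nM, with a range of 15000 nM to 100000 nM, and it may well be reported only as inactive.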

Compound 4, half-maximal inhibitory concentration: 30000 nM
Beside the measured number, compound 4's estimate is 1.3-fold (0.12 log units) above it, and the stated range covers the measured number.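

Within the data shown here, compound 2 carries no number in this assay, so no step to compound 4 can be read. The compounds shown leave open whether benzyloxy changes the number on the core of compound 2. Nothing measured here offers a cause.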